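Cytotoxicity on MT4 cells across three quinazoline ethers

The source may hold more compounds than are shown below. What is called first, only, known or untested is meant among the compounds shown, and "the series" means these compounds.

Measured compounds:
- compound 1, `COc1ccccc1Oc1nc(Nc2ccc(C#N)cc2)nc2ccccc12`: 150000 nM
- compound 2, `COc1ccc(Oc2nc(Nc3ccc(C#N)cc3)nc3ccccc23)cc1`: 340000 nM

In an ADME assay on MT4 cells (Homo sapiens) for cytotoxicity, read by MTT assay, with a stated time of 4 days (on this read-out lower numbers stand for higher toxicity in this test and higher numbers for lower toxicity in this test), compound 1 gives 150000 nM and compound 2 gives 340000 nM. Within the data shown here, compound 2 stands highest of the two numbers, the only neighbour being compound 1, the step between them being a 2.3-fold higher number from compound 1 to compound 2 (0.36 log units; beyond the scatter). Compound 3, `Cc1cccc(C)c1Oc1nc(Nc2ccc(C#N)cc2)nc2ccccc12`, has not been measured in this assay. It differs from compound 2 by 2,6-dimethylphenyl in place of 4-methoxyphenyl on an oxygen on an aromatic ring. Among the measured compounds shown here, the single measured step concerns moving the methoxy group on the aryl ether and does not bear directly on an exchange of methoxy for two methyl groups; it shows only that changes at this position have so far moved the number modestly. For the measured compounds named here, with no step bearing on this change, the expectation for compound 3 is no step beyond the scatter, a 1.4-fold lower number from compound 2 to compound 3 (0.13 log units; within the scatter), so compound 3 is estimated at 250000 nM, with a range from 100000 nM to 600000 nM.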

Compound 3, half-maximal cytotoxic concentration: 35000 nM
Beside the measured number, compound 3's estimate is 7.1-fold (0.85 log units) above it; measured number below the stated range.
By their numbers in this assay, from the lowest: compound 3; then compound 1; then compound 2.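

With the change from 4-methoxyphenyl to 2,6-dimethylphenyl on the ether oxygen, this assay shows that this position can shift the number further than moving the methoxy group did (a 2.3-fold higher number from compound 1 to compound 2 (0.36 log units; beyond the scatter)), with a drop of a size the earlier pair had not shown (a 9.7-fold lower number from compound 2 to compound 3 (0.99 log units; beyond the scatter)). The fall also holds against the 2-methoxyphenyl ether (a 4.3-fold lower number from compound 1 to compound 3 (0.63 log units; beyond the scatter)), so compound 3 has the lowest number of the three and is the most toxic in this test, with both of its steps beyond the scatter. Nothing available explains this drop.

The compounds shown leave open whether the drop goes with the two methyl groups or with the loss of the methoxy group. They also leave open how a 2-methylphenyl or a 4-aminophenyl group would read at this place.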